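Swapping 4-chlorophenyl for 2-methylphenyl in compound 3

The source may report more compounds than this note shows. Statements on the series, on what has been measured and on what is new or still open speak of the compounds shown alone.

- compound 1 `COc1ccc(/C=C/c2cc(OC)cc(OC)c2/C=C/C(=O)c2ccc(N)cc2)cc1` gives 3.8 ug/mL
- compound 2 `COc1ccc(/C=C/c2cc(OC)cc(OC)c2/C=C/C(=O)c2ccc(Cl)cc2)cc1` gives 6.4 ug/mL

In a functional assay on A549 cells (Homo sapiens) for antiproliferative activity, read by MTT assay, with a stated time of 48 h (on this read-out higher numbers stand for weaker inhibition and lower numbers for stronger inhibition), compound 2 gives 6.4 ug/mL and compound 1 gives 3.8 ug/mL so the two numbers lie within the usual scatter of each other. Within the data shown here, with only this pair measured, compound 2 has no clear rank.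

The next compound, compound 3 `COc1ccc(/C=C/c2cc(OC)cc(OC)c2/C=C/C(=O)c2ccccc2C)cc1`, keeps the shared core and changes in one place (2-methylphenyl in place of 4-chlorophenyl on a carbonyl carbon). In words, 2-methylphenyl stands in place of 4-chlorophenyl on a carbonyl carbon.

Among the measured compounds shown here, only one measured step bears on this change. It puts chloro in place of amino on an aromatic carbon, and it is a 1.7-fold higher number from compound 1 to compound 2 (0.23 log units; within the scatter) as a result. For the measured compounds named here, that step touches the same aryl group, but no measured compound carries a methyl group, so the evidence is thin. With nothing pointing either way, no shift beyond the scatter is expected in this assay from this swap. The estimate is a 1.2-fold lower number from compound 2 to compound 3 (0.07 log units; within the scatter) and it is expected to be no real change. Compound 3 is estimated at 5.5 ug/mL with a range from 2.5 ug/mL to 13 ug/mL expected.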

Compound 3, half-maximal inhibitory concentration: 5.9 ug/mL
Compound 3: the middle estimate sits 1.1-fold (0.03 log units) below what was measured; low and high end bracket the measured number.
By their numbers in this assay, from the lowest: compounds 1, 3 and 2 (each within the scatter of the next).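

Among these compounds, at this place on the carbonyl carbon, a methyl group now appears for the first time, and a substituent sits at a different ring position from those before. In this assay, 2-methylphenyl in place of 4-chlorophenyl gives (a 1.1-fold lower number from compound 2 to compound 3 (0.04 log units; within the scatter)), and 2-methylphenyl in place of 4-aminophenyl gives (a 1.6-fold higher number from compound 1 to compound 3 (0.19 log units; within the scatter)). All three aryl groups shown therefore lie within the usual scatter of one another, so neither swapping the substituent nor moving it from the 4-position to the 2-position has yet produced a readable shift, and nothing shown accounts for why these groups read alike.

Still open, on these data alone, is whether any group on this aryl ring can move the number beyond the scatter, for example a carboxylic acid, a morpholine or a longer alkyl chain. It is also unclear how 4-methylphenyl or 2-chlorophenyl would read, and that pair would separate the identity of the substituent from its place on the ring, which compound 2 and compound 3 change together.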